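Removing a Methyl from a Tethered Hydroxamic Acid

The source may hold more compounds than are shown below. What is called first, only, known or untested is meant among the compounds shown, and "the series" means these compounds.

Compound 1, `CCN(C(=O)c1cc(C(C)C)c(O)cc1O)c1ccc(NC(=O)CCCCCCC(=O)NO)cc1`, carries a hydroxamic acid at the end of a long chain, joined through an amide to one ring, which is in turn linked by a second amide to a hydroxyl-bearing ring. In a functional assay on HCT-116 cells (Homo sapiens) for inhibition, read by sulforhodamine B assay, with a stated time of 48 h (a lower number here means a stronger inhibitor of growth, a higher number a weaker inhibitor of growth), compound 1 gives 3560 nM. Compound 2, `CC(C)c1cc(C(=O)N(C)c2ccc(NC(=O)CCCCCCC(=O)NO)cc2)c(O)cc1O`, differs from compound 1 in a single spot: hydrogen in place of methyl on a saturated chain carbon bound to an amide-type nitrogen. That change brought a 4.3-fold lower number from compound 1 to compound 2 (0.63 log units; beyond the scatter).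

Compound 3, `CCN(C(=O)c1cc(C(C)C)c(O)cc1O)c1cccc(NC(=O)CCCCCCC(=O)NO)c1`, is built from the same atoms as compound 1 but joined differently; the difference between the two cores is not broken down here. In this assay compound 3 gives 1120 nM, and compound 2 gives 830 nM; these two values lie within the scatter of each other, so nothing separates them.

Compound 4, `CC(C)c1cc(C(=O)N(C)c2cccc(NC(=O)CCCCCCC(=O)NO)c2)c(O)cc1O`, has not yet been measured. It stands to compound 3 exactly as compound 2 stands to compound 1: hydrogen in place of methyl on a saturated chain carbon bound to an amide-type nitrogen. The place of the change is described in the same words for both pairs, so this is the same change carried onto the other core. Going by the values given here, for compound 4 a step of a 3.7-fold lower number from compound 3 to compound 4 (0.57 log units; beyond the scatter) is expected, because the one earlier instance of this change gave a 4.3-fold lower number from compound 1 to compound 2 (0.63 log units; beyond the scatter). Among the compounds with values here, only that single precedent supports the expectation, so some caution is warranted. Compound 4 is therefore estimated at 300 nM, with a likely range from 120 nM to 750 nM.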

Compound 4, concentration for 50% growth inhibition: 1170 nM
Compound 4: middle estimate off by 3.9-fold (0.59 log units), on the low side, outside the stated range (above it).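

On the second core, the same swap of methyl for hydrogen gave a 1.0-fold higher number from compound 3 to compound 4 (0.02 log units; within the scatter) in this assay, so the clear step seen on the first core did not appear again. Set side by side, the two steps differ by more than repeat measurements would explain, which shows that in this series the size of this change depends on the core that carries it: the same change on two cores in this assay, a 4.3-fold lower number (0.63 log units; beyond the scatter) from compound 1 to compound 2 and a 1.0-fold higher number (0.02 log units; within the scatter) from compound 3 to compound 4, 4.5-fold (0.65 log units) apart, beyond the scatter of two such steps What this does not show is why the two cores behave differently, and with only two pairs it cannot say which of the two outcomes would be the more usual on a further core.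

The compounds shown carry only an ethyl or a methyl on the amide-type nitrogen, so it remains open how either core would respond to a propyl group, a longer chain or a bare amide hydrogen at that place. As far as these compounds go, it also remains open whether the gap between the two steps would persist with a carboxylic acid in place of the hydroxamic acid at the end of the chain.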